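Swapping fluorine for methyl on a cyclopropyl amide

The source may hold more compounds than are shown below. What is called first, only, known or untested is meant among the compounds shown, and "the series" means these compounds.

Measured so far:
compound 1 `O=C(CC1C=CCC1)N1CC2CC(C1)N2`: 53 nM
compound 2 `O=C([C@H]1C[C@H]1F)N1CC2CC(C1)N2`: 1.1 nM

Both compounds share a bicyclic amine core carrying an amide on one nitrogen. In an assay on SH-EP1 cells for displacement of a labelled ligand from Neuronal acetylcholine receptor; alpha4/beta2 (Homo sapiens), read by scintillation counting (a lower number here means a stronger inhibitor, a higher number a weaker inhibitor), compound 1 gives 53 nM, while compound 2 gives 1.1 nM, the lower of the two numbers, and the gap between them lies well beyond the usual scatter of this assay. Compound 3 `C[C@@H]1C[C@H]1C(=O)N1CC2CC(C1)N2` has not yet been measured. It keeps the core and the amide carbonyl of compound 2 and differs only in the group on the carbonyl carbon: 2-methylcyclopropyl in place of 2-fluorocyclopropyl on a carbonyl carbon. Going by the values given here, no measured pair here shows what a fluorine-to-methyl swap on this small ring does, so the expectation rests on the value of compound 2 alone. A small loss is expected, with the step of a 2.7-fold higher number from compound 2 to compound 3 (0.44 log units; beyond the scatter) staying modest. Compound 3 is thus estimated at 3 nM, within a range from 0.8 nM to 15 nM.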

Compound 3, inhibition constant: 1 nM
For compound 3 the middle estimate is 3.0-fold (0.48 log units) above the measured one; low and high end bracket the measured number.
By their numbers in this assay, from the lowest: compounds 3 and 2 (each within the scatter of the next); then compound 1.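

In this assay the exchange of 2-fluorocyclopropyl for 2-methylcyclopropyl on a carbonyl carbon gives a 1.1-fold lower number from compound 2 to compound 3 (0.04 log units; within the scatter) and so leaves the reading effectively unchanged. Going by these compounds alone, this is the first comparison here of two compounds that differ in one place, and it shows that the fluorine on this small ring is not required for a strong binding number, as a carbon-only group with the same heavy-atom count reads alike. No measurement shown here explains why the two groups match. As far as these compounds go, whether a plain cyclopropyl without any substituent, a hydroxymethyl group on the ring or a longer chain such as n-butyl would read the same remains open. Equally open, from the compounds shown here alone, is how the other stereoisomers of 2-methylcyclopropyl would compare.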